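This account rests on a few compounds, and the source may have more. Where it says the series, first, only, none or still open, it means among the compounds named here.

Measured compounds in hand:

compound 1, `O=C(O)/C=C/c1cc(O)c(O)c(O)c1`: 87900 nM
compound 2, `CCCCCCNC(=O)/C=C/c1ccc(O)c(O)c1`: 22000 nM

Both numbers come from a functional assay on C2BBe1 cells (Homo sapiens) for cytotoxicity, read by sulforhodamine B assay, with a stated time of 48 h; a higher number here means a weaker inhibitor, a lower number a stronger inhibitor. In this assay compound 1 gives 87900 nM and compound 2 gives 22000 nM. Compound 2 stands with the lowest number of the two; compound 1 sits higher, and that gap lies beyond the usual scatter. The two structures differ in more than one place, so the gap is not read as a single step.

The next compound in the series is compound 3, `CCCCCCNC(=O)/C=C/c1cc(O)c(O)c(O)c1`, still to be measured in this assay. It differs from compound 2 in one place: hydroxy in place of hydrogen on an aromatic carbon. The hexyl amide of compound 2 is kept; only the ring substitution changes, giving the same trihydroxy pattern that compound 1 carries.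

Among the compounds with values here, no measured step isolates this change. Within the data shown here, compound 1, the only other compound with three hydroxy groups, gives the higher number, but it also lacks the amide, so it cannot fix the size of the step. The expectation is a small step from compound 2 to compound 3, a 1.2-fold higher number from compound 2 to compound 3 (0.07 log units; within the scatter), probably within the scatter, with a slight lean toward a higher number. Compound 3 is estimated at 26000 nM, with a range from 10000 nM to 65000 nM.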

Compound 3, half-maximal inhibitory concentration: 115000 nM
Estimate against measurement, compound 3: 4.4-fold (0.65 log units) below, outside the stated range (above it).
By their numbers in this assay, from the lowest: compound 2; then compounds 1 and 3 (each within the scatter of the next).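

Within this assay, hydroxy in place of hydrogen on an aromatic carbon, ortho to a hydroxy group, meta to a hydroxy group and meta to a large group, gives a 5.2-fold higher number from compound 2 to compound 3 (0.72 log units; beyond the scatter), the first single-change step available in this series. This position is therefore not neutral: with the hexyl amide held constant, the added hydroxy alone moves the number upward, toward weaker inhibition, and the lower number of compound 2 depends on the ring substitution as well as on the amide side of the molecule. No data on hand bear on the reason for this step.

On these data alone, the step rests on one pair and one hexyl amide, so it remains open whether a butyl chain or an octyl chain in place of the hexyl chain would show a step of the same size and direction. As far as these compounds go, it is also open whether the step belongs to the added hydroxy specifically, a question that a methoxy group or a fluorine atom at the same position on the ring would address.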